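Changing one sulfonyl group of compound 1

The source may hold more compounds than are shown below. What is called first, only, known or untested is meant among the compounds shown, and "the series" means these compounds.

In a functional assay on HT-29 cells (Homo sapiens) for cytotoxicity, read by resazurin assay, with a stated time of 48 h (a lower number here means that less compound is needed, a higher number that more compound is needed for the effect), compound 1 (`COc1ccc(S(=O)(=O)Nc2ccc(-c3nc4cc(NS(=O)(=O)c5ccc(OC)cc5)ccc4o3)cc2)cc1`) gives 40000 nM, and compound 3 (`O=S(=O)(Nc1ccc(-c2nc3cc(NS(=O)(=O)c4cccc5ccccc45)ccc3o2)cc1)c1cccc2ccccc12`) gives 31000 nM, a value within the scatter of compound 1. Together, these two sit at the high end of the numbers measured so far. Compound 2 (`O=S(=O)(Nc1ccc(-c2nc3cc(NS(=O)(=O)c4ccccc4Cl)ccc3o2)cc1)c1ccccc1Cl`) gives 15000 nM, a lower number that lies beyond the scatter from compound 1.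

Compound 4 (`COc1ccc(S(=O)(=O)Nc2ccc3oc(-c4ccc(NS(=O)(=O)c5cc(Br)ccc5OC)cc4)nc3c2)cc1`) has not yet been measured. It differs from compound 1 at one place, with 5-bromo-2-methoxyphenyl in place of 4-methoxyphenyl on a sulfonyl sulfur. Going by the values given here, no measured pair differs in just one place, so the three values are the only guide to the size of this step. Across the groups carried on the sulfonyl sulfurs of these compounds, the values spread no wider than compound 2 at 15000 nM and compound 1 at 40000 nM. A modest step in this assay is therefore expected, toward a lower number if it shows at all, and probably not beyond the scatter. The estimated change is a 1.6-fold lower number from compound 1 to compound 4 (0.20 log units; within the scatter). For compound 4, the expected value is 25000 nM, with an estimated range from 9000 nM to 60000 nM.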

Compound 4, half-maximal effective concentration: 14000 nM
The estimate for compound 4 lay 1.8-fold (0.25 log units) above the measured number, within the range that was stated.
By their numbers in this assay, from the lowest: compounds 4 and 2 (each within the scatter of the next); then compounds 3 and 1 (each within the scatter of the next).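

In this assay, going by these compounds alone, the exchange of 4-methoxyphenyl for 5-bromo-2-methoxyphenyl on one sulfonyl sulfur is the first change in a single place that can be read, and it brings a 2.9-fold lower number from compound 1 to compound 4 (0.46 log units; beyond the scatter) on its own. Within the data shown here, this position is therefore not silent: altering the group on this one sulfonyl sulfur, while the other sulfonyl group keeps its 4-methoxyphenyl, is enough to move the number beyond the scatter, something the earlier compounds could not show, since they differ from one another at both sulfonyl groups. Nothing available explains why the number moves.

The change holds two differences at once, the added bromine and the methoxy in its new place, and the compounds shown do not tell which of them carries the step or what 2-methoxyphenyl alone would give. They also leave open whether an amine or a carboxylic acid on this phenyl ring, or a plain methyl in place of the ring, would shift the number further, and whether the same exchange on the other sulfonyl sulfur would have a similar effect.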